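The source may report more compounds than this note shows. Statements on the series, on what has been measured and on what is new or still open speak of the compounds shown alone.

Measured compounds:
compound 1 `COc1cc(/C=C/Cc2cc(O)c3ccoc3c2)cc(OC)c1OC` — 27700 nM
compound 2 `COc1cc(/C=C/Cc2cc(OC)c3ccoc3c2)cc(OC)c1OC` — 75000 nM
compound 3 `COc1cc(/C=C\Cc2cc(O)c3ccccc3c2)cc(OC)c1OC` — 670 nM

In a functional assay on BMEC cells (Bos taurus) for antiproliferative activity (on this read-out lower numbers stand for stronger inhibition and higher numbers for weaker inhibition), compound 1 gives 27700 nM and compound 2 gives 75000 nM, while compound 3 gives 670 nM and stands lowest of the three, well clear of both others. The difference between the core of compound 1 and the core of compound 3 is not broken down here. Compound 4 `COc1cc(/C=C\Cc2cc(OC)c3ccccc3c2)cc(OC)c1OC` has not yet been measured. It differs from compound 3 by methyl in place of hydrogen on an oxygen on an aromatic ring, and the same change separates compound 1 from compound 2, (methyl in place of hydrogen on an oxygen on an aromatic ring), where it gave a 2.7-fold higher number from compound 1 to compound 2 (0.43 log units; beyond the scatter). For compound 4 the same change is expected to produce a 2.7-fold higher number from compound 3 to compound 4 (0.43 log units; beyond the scatter) in this assay. That expectation rests on a single pair, compound 1 and compound 2 with a 2.7-fold higher number from compound 1 to compound 2 (0.43 log units; beyond the scatter), and the cores are not the same, so it is held loosely. Compound 4 is therefore expected near 1800 nM, with a likely range from 700 nM to 5500 nM in this assay.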

Compound 4, half-maximal inhibitory concentration: 10000 nM
The estimate for compound 4 lay 5.6-fold (0.74 log units) below the measured number; the measured number lies above the stated range.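

In this assay, methyl in place of hydrogen on the oxygen gives a 15-fold higher number from compound 3 to compound 4 (1.17 log units; beyond the scatter), so the number rises on both cores, but the size of the step does not carry over: the same change on two cores in this assay, a 2.7-fold higher number (0.43 log units; beyond the scatter) from compound 1 to compound 2 and a 15-fold higher number (1.17 log units; beyond the scatter) from compound 3 to compound 4, 5.5-fold (0.74 log units) apart, beyond the scatter of two such steps In this series, hydroxy to methoxy costs more on the core of compound 3 than on the core of compound 1, and a step size read on one core is a poor guide to the other. Among the compounds shown here, with only two pairs, and with the difference between the two cores not broken down, the data do not show which part of the core sets the size of the step, or what size would appear on a further core.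

The compounds shown carry only hydroxy or methoxy at this place, so it remains open how an amine or a longer chain such as ethoxy would behave there in this assay. As far as these compounds go, it also remains open whether such groups would show the same gap between the two cores.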